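Cyclopropyl for Ethynyl: an Expected Shift in Binding

The source may report more compounds than this note shows. Statements on the series, on what has been measured and on what is new or still open speak of the compounds shown alone.

Three compounds have been measured in an assay for binding affinity to Indoleamine 2,3-dioxygenase 1 (Homo sapiens), read by spectrophotometry, with a stated time of 30 min; a lower number here means tighter binding, a higher number weaker binding:

Compound 1, `C[Si](C)(C)c1cccc2[nH]ncc12`: 43000 nM
Compound 2, `OC(Cc1ccccc1)c1cc(Br)cc2[nH]ncc12`: 140 nM
Compound 3, `C#Cc1cc(C(O)Cc2ccccc2)c2cn[nH]c2c1`: 1300 nM

Compound 3 holds the second highest of the three numbers. Among the compounds with values here, its nearest neighbour is compound 2, the change being a 9.3-fold higher number from compound 2 to compound 3 (0.97 log units; beyond the scatter); its furthest is compound 1, whose number is higher still, and the two values show only that compound 1 binds far more weakly.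

Compound 4, `OC(Cc1ccccc1)c1cc(C2CC2)cc2[nH]ncc12`, differs from compound 3 by cyclopropyl in place of ethynyl on an aromatic carbon. Within the data shown here, the only measured step at this same position is a 9.3-fold higher number from compound 2 to compound 3 (0.97 log units; beyond the scatter), a modest rise beyond the scatter. Among the measured compounds shown here, no measured step involves cyclopropyl, so its effect is open. Since the position tolerates both bromo and ethynyl, a step in this assay of modest size, in either direction, or none beyond the scatter, seems plausible.

Compound 4 is therefore expected to give about 500 nM, between 120 nM and 2500 nM, which means an expected step of a 2.6-fold lower number from compound 3 to compound 4 (0.41 log units; beyond the scatter).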

Compound 4, dissociation constant: 1200 nM
Beside the measured number, compound 4's estimate is 2.4-fold (0.38 log units) below it; the measured number falls inside the stated range.
By their numbers in this assay, from the lowest: compound 2; then compounds 4 and 3 (each within the scatter of the next); then compound 1.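

In this assay there is a 1.1-fold lower number from compound 3 to compound 4 (0.03 log units; within the scatter), so at this position on the six-membered aromatic ring, ethynyl and cyclopropyl cannot be told apart, even though one is a triple bond outside aromatic rings and the other a three-membered ring of carbon only. Bromo stands apart from both, with an 8.6-fold higher number from compound 2 to compound 4 (0.93 log units; beyond the scatter) matching in direction a 9.3-fold higher number from compound 2 to compound 3 (0.97 log units; beyond the scatter), so compound 2 alone lies beyond the scatter of the other two carbon-substituted compounds in this series. Nothing available here accounts for the separation of bromo from the two carbon groups.

Still open, from the compounds shown here alone, is how other groups at this position would compare with bromo, such as chloro, an amine or a longer alkyl chain. It is also open whether the same relation among these three groups would hold if the hydroxyl-bearing side chain were replaced.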